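Lengthening the aryl alkyl chain toward compound 3

The source may report more compounds than this note shows. Statements on the series, on what has been measured and on what is new or still open speak of the compounds shown alone.

Compound 1 `CCc1ccc(C(=O)CC(SCC(=O)O)C(=O)O)cc1` and compound 2 `CCCCc1ccc(C(=O)CC(SCC(=O)O)C(=O)O)cc1` share one core and differ only in the chain carried on the aromatic ring. In a functional assay on HeLa cells (Homo sapiens) for inhibition (on this read-out higher numbers stand for weaker inhibition and lower numbers for stronger inhibition), compound 1 gives 4790 nM. In this assay compound 2 gives 1920 nM. The step of a 2.5-fold lower number from compound 1 to compound 2 (0.40 log units; beyond the scatter) is the only one measured so far, and compound 2 therefore stands lowest of the two numbers, with compound 1 as its nearest neighbour at a higher number.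

Compound 3 `CCCCCCCCCCCCc1ccc(C(=O)CC(SCC(=O)O)C(=O)O)cc1` has not yet been measured in this assay. It differs from compound 2 by octyl in place of hydrogen on a saturated chain carbon, four bonds along the chain from an aromatic carbon; cut one bond further out, the same difference reads methyl to nonyl or ethyl to decyl. Among the compounds with values here, the one step that bears on this change, a 2.5-fold lower number from compound 1 to compound 2 (0.40 log units; beyond the scatter), also lengthened the chain on that ring and was modest. The present change adds a far longer chain, and whether the number keeps falling over such a span cannot be read from a single step. A continued but uncertain fall is expected, estimated as a 2.1-fold lower number from compound 2 to compound 3 (0.33 log units; beyond the scatter). In this assay compound 3 is expected near 900 nM, with a range from 250 nM to 3500 nM.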

Compound 3, half-maximal inhibitory concentration: 1710 nM
For compound 3 the middle estimate is 1.9-fold (0.28 log units) below the measured one, and the stated range covers the measured number.
By their numbers in this assay, from the lowest: compounds 3 and 2 (each within the scatter of the next); then compound 1.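

Adding octyl at this place, four bonds along the chain from an aromatic carbon, gives a 1.1-fold lower number from compound 2 to compound 3 (0.05 log units; within the scatter) in this assay, so compound 2 and compound 3 cannot be told apart on this read-out, and the fall seen with the first lengthening does not carry on across this much longer extension. Taken from the shorter end of the set, the decyl change gives a 2.8-fold lower number from compound 1 to compound 3 (0.45 log units; beyond the scatter), so the only differences beyond the scatter among these three compounds are those that separate compound 1 from compound 2 and compound 3. Nothing available explains why the numbers behave this way at this place.

The compounds shown leave open whether a hexyl or octyl chain on the ring would give a number distinct from those of compound 2 and compound 3, and whether a longer chain still would leave the number where it stands. They also leave open whether a chain ending in an amine or a carboxylic acid would follow the plain alkyl chains on this read-out.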